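Aryl swap on the anilinic nitrogen of the acid series

The compounds below may be only part of what the source reports. "The series", "measured", "known", "first", "only" and "open" are said of these compounds alone.

Compound 1 `COc1cc(N(CC2CC2)c2cccc(C(F)(F)F)c2)cnc1C(=O)[C@H]1C[C@@H]1C(=O)O` is the reference point. Among the measured compounds shown here, in an assay for inhibition of leukotriene C4 synthase (Homo sapiens), read by LC-MS, with stated times of 15 min and 30 min (on this read-out higher numbers stand for weaker inhibition and lower numbers for stronger inhibition), compound 1 gives 6.42 nM, the lowest of the two numbers measured so far. For the measured compounds named here, compound 2 `CCN(c1cccc(C(F)(F)F)c1)c1cnc(C(=O)[C@H]2C[C@@H]2C(=O)O)c(OC)c1` is the only neighbour with a single change, and in this assay compound 2 gives 13 nM; the step of a 2.0-fold higher number from compound 1 to compound 2 (0.31 log units; beyond the scatter) is the only measured step in the set and it concerns the saturated chain carbon bound to the nitrogen, not the aryl group. Compound 3 `COc1cc(N(CC2CC2)c2cc(Cl)ccc2F)cnc1C(=O)[C@H]1C[C@@H]1C(=O)O` is not yet measured; it differs from compound 1 by 5-chloro-2-fluorophenyl in place of 3-(trifluoromethyl)phenyl on a nitrogen on an aromatic ring. Going by the values given here, no measured step touches this aryl group, so the single step from compound 1 to compound 2 offers only a sense of scale for one-place changes. A modest step toward weaker inhibition is therefore expected, a 2.3-fold higher number from compound 1 to compound 3 (0.37 log units; beyond the scatter), with wide uncertainty. Compound 3 is estimated at 15 nM, in a range from 4 nM to 60 nM.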

Compound 3, half-maximal inhibitory concentration: 3.71 nM
Compound 3: the middle estimate sits 4.0-fold (0.61 log units) above what was measured, outside the stated range (below it).
By their numbers in this assay, from the lowest: compounds 3 and 1 (each within the scatter of the next); then compound 2.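

Among the compounds shown here, at the aryl group on the nitrogen on an aromatic ring, the first measured change in this assay is a 1.7-fold lower number from compound 1 to compound 3 (0.24 log units; within the scatter) and so leaves the two compounds indistinguishable on this read-out. Inhibition at the level of compound 1 therefore does not depend on 3-(trifluoromethyl)phenyl at this place, since 5-chloro-2-fluorophenyl, with fewer heavy atoms and no trifluoromethyl group, serves as well here. No supporting data bear on the reason for this result.

The compounds shown do not separate the contributions of the chlorine and the fluorine, and they do not show whether the aryl swap would read the same with the ethyl group of compound 2 on the nitrogen. As far as these compounds go, how a phenyl ring carrying a nitrile would read at this place also remains open.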